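The compounds below may be only part of what the source reports. "The series", "measured", "known", "first", "only" and "open" are said of these compounds alone.

Compound 1 `O=C(CN(c1ncnc2c1ncn2C1CCCCO1)C1CC1)N[C@@H](CO)C(=O)OCc1ccccc1` gives 32.2% in a functional assay on the whole organism (Tail, strain ICR) with Mus musculus as the target, in the tail flick test, with a stated time of 90 min, at a dose of 25 umol/kg by the oral route; on this read-out higher numbers stand for a stronger effect at the one dose given and lower numbers for a weaker effect. That is the second highest of the three numbers in hand: compound 2 `N=C(N)NCCC[C@H](NC(=O)CN(c1nc(Cl)nc2[nH]cnc12)C1CC1)C(=O)OCc1ccccc1` gives 30.4%, within the scatter of compound 1, while compound 3 `O=C(CN(c1nc(Cl)nc2[nH]cnc12)C1CC1)N[C@@H](CCC(=O)OCc1ccccc1)C(=O)OCc1ccccc1` gives 50%, beyond it. Among the compounds with values here, the only step measured so far, a number 19.6 percentage points higher from compound 2 to compound 3 (beyond the scatter), concerns a change on a saturated chain carbon three bonds along the chain from an amide-type nitrogen and a carbonyl carbon. Compound 4 `O=C(CN(c1ncnc2c1ncn2C1CCCCO1)C1CC1)NCC(=O)OCc1ccccc1` differs from compound 1 by hydrogen in place of hydroxymethyl on a saturated chain carbon bound to an amide-type nitrogen and a carbonyl carbon. Within the data shown here, no measured step touches this place, so these numbers give no ground for a shift beyond the scatter. Compound 4 is therefore expected to give 28%, between 14% and 42%. This amounts to an expected step of a number 4.2 percentage points lower from compound 1 to compound 4 (within the scatter).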

Compound 4, a percentage reported as activity, at one dose (the size of the read-out at that dose, not a potency): 25.9%
The estimate for compound 4 lay 2.1 percentage points above the measured number; the range from low to high includes it.
By their numbers in this assay, from the lowest: compounds 4, 2 and 1 (each within the scatter of the next); then compound 3.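

Within the data shown here, replacing hydroxymethyl with hydrogen on the saturated chain carbon bound to an amide-type nitrogen and a carbonyl carbon gives a number 6.3 percentage points lower from compound 1 to compound 4 (within the scatter) and is the first step read at this place. On the core of compound 1, this side chain can therefore go without a clear change in the read-out at this one dose. Nothing at hand explains this result.

From the compounds shown here alone, whether an amine, a carboxylic acid or a longer chain at this carbon would move the number beyond the scatter stays open. Compound 2 and compound 3 cannot settle this, since their cores differ from that of compound 1.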